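The source may hold more compounds than are shown below. What is called first, only, known or untested is meant among the compounds shown, and "the series" means these compounds.

Going by the values given here, in a functional assay on SH-SY5Y cells (Homo sapiens) for cytotoxicity, read by MTT assay, with a stated time of 48 h (a higher number here means a weaker inhibitor, a lower number a stronger inhibitor), compound 1 `COc1cc(/C=C/C(=O)/C=C/c2nc3cc(C)ccc3n2C)ccc1O` gives 4700 nM as the lower of the two numbers so far, while compound 2 `COc1cc(/C=C/C(=O)/C=C/c2nc3c(C)c(C)ccc3n2C)ccc1O` gives 19000 nM in the same read-out. Compound 3 `COc1cc(/C=C/C(=O)/C=C/c2nc3cc(Cl)ccc3n2C)ccc1O` has not been measured and carries chloro in place of methyl on an aromatic carbon. Among the compounds with values here, the one measured step is a 4.0-fold higher number from compound 1 to compound 2 (0.61 log units; beyond the scatter) for methyl in place of hydrogen on an aromatic carbon, a different change that bears only indirectly. Within the data shown here, no chloro compound has been measured, so a step no larger than that modest one, with no firm direction, is expected in this assay here. The estimated step is a 1.1-fold higher number from compound 1 to compound 3 (0.03 log units; within the scatter) for this exchange. Compound 3 is expected at 5000 nM within a range of 2000 nM to 13000 nM in this estimate.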

Compound 3, half-maximal inhibitory concentration: 4700 nM
The estimate for compound 3 lay 1.1-fold (0.03 log units) above the measured number, and the stated range covers the measured number.
By their numbers in this assay, from the lowest: compounds 1 and 3 (each within the scatter of the next); then compound 2.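

In this assay, chloro in place of methyl on the aromatic carbon gives no change at the digits printed from compound 1 to compound 3 (within the scatter), so at this position the assay does not separate the two groups. The earlier step, a 4.0-fold higher number from compound 1 to compound 2 (0.61 log units; beyond the scatter), was a different change, methyl in place of hydrogen, and it moved the number beyond the scatter. Nothing available explains why methyl and chloro read alike here. The compounds shown leave open whether an amine, a methoxy group or a carboxylic acid at this position would also read alike, and how plain hydrogen there would compare.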